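Benzothiazolyl thioether anilides against thiosulfate sulfurtransferase

The compounds below may be only part of what the source reports. "The series", "measured", "known", "first", "only" and "open" are said of these compounds alone.

Of the compounds shown here, three have been measured in an assay on isolated protein for inhibition of thiosulfate sulfurtransferase (Homo sapiens), with a stated time of 60 min, in the absence of a further agent (a higher number here means a weaker inhibitor, a lower number a stronger inhibitor), and each of them reached only a limit of the measurement rather than a number.

Compound 1, `O=C(Nc1ccc(Sc2nc3ccccc3s2)c(Cl)c1)c1ccccc1O`, gives the limit > 100000 nM.
Compound 2, `O=C(Nc1ccc(Sc2nc3ccccc3s2)cc1)c1cccc(Br)c1`, gives the limit > 100000 nM.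
Compound 3, `O=C(Nc1ccc(Sc2nc3ccccc3s2)cc1)c1cc(Br)ccc1O`, gives the limit > 100000 nM.

The change from compound 3 to compound 2, (hydrogen in place of hydroxy on an aromatic carbon), makes the step that the two limits leave unreadable from compound 3 to compound 2 because of the limit of > 100000 nM in this assay, at which 3 of the 3 values shown sit. The difference between the cores of compound 1 and compound 3 is not broken down here. Compound 4, `O=C(Nc1ccc(Sc2nc3ccccc3s2)c(Cl)c1)c1ccccc1`, is not yet measured in this assay. It differs from compound 1 by hydrogen in place of hydroxy on an aromatic carbon, the same kind of change as that from compound 3 to compound 2, although there the place is also para to a bromo group. Because compound 1 gives only the limit > 100000 nM, the step that the limit leaves unreadable from compound 1 to compound 4 is expected to leave compound 4 at that limit too. Compound 4 is estimated at 150000 nM, between 50000 nM and 500000 nM.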

Compound 4, half-maximal inhibitory concentration: > 100000 nM
Compound 4: no number, only a limit; the forecaster's own chance of this, stated with the estimate: 85%; the middle value lies beyond the limit too.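

No step can be read between compound 1 and compound 4, because both reached only a limit of the measurement: the limit of > 100000 nM in this assay, at which 4 of the 4 values shown sit.

Compounds 1 to 4 leave open whether hydroxy or any other change shown affects inhibition in this assay.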